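A para-methyl added to the anilino ring of compound 1

The compounds below may be only part of what the source reports. "The series", "measured", "known", "first", "only" and "open" are said of these compounds alone.

Compound 1 `S=c1oc(-c2ccc3c(c2)OCCO3)nn1CNc1ccccc1` is measured in a functional assay, with a stated time of 6 min (a higher number here means a weaker inhibitor, a lower number a stronger inhibitor), where compound 1 gives 5140 nM. Going by the values given here, of the three compounds measured so far it gives the lowest number, but compound 2 `CCOc1ccccc1NCn1nc(-c2ccc3c(c2)OCCO3)oc1=S` with 5280 nM lies within the scatter of it, while compound 3 `S=c1oc(-c2ccc3c(c2)OCCO3)nn1CNc1ccccc1Br` with 12700 nM lies beyond it. Compound 4 `Cc1ccc(NCn2nc(-c3ccc4c(c3)OCCO4)oc2=S)cc1` differs from compound 1 by methyl in place of hydrogen on an aromatic carbon. Among the compounds with values here, no measured step places a group at this position. The nearest comparisons are the steps at another position on the same ring: a 1.0-fold higher number from compound 1 to compound 2 (0.01 log units; within the scatter), and a 2.5-fold higher number from compound 1 to compound 3 (0.39 log units; beyond the scatter). A small group on this ring therefore looks tolerated to modestly weakening, so little change beyond the scatter is expected, a 1.2-fold higher number from compound 1 to compound 4 (0.07 log units; within the scatter). Compound 4 is estimated at 6000 nM, within 3000 nM to 12000 nM.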

Compound 4, half-maximal inhibitory concentration: 5700 nM
Compound 4: middle estimate off by 1.1-fold (0.02 log units), on the high side; measured number inside the range.
By their numbers in this assay, from the lowest: compounds 1, 2 and 4 (each within the scatter of the next); then compound 3.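

In this assay, going by these compounds alone, methyl is the first group seen para to the large group on this ring, and it leaves the number within the scatter: a 1.1-fold higher number from compound 1 to compound 4 (0.04 log units; within the scatter). Two further steps change both the group and where it sits, so they cannot isolate this position: a 1.1-fold higher number from compound 2 to compound 4 (0.03 log units; within the scatter), which is within the scatter, and a 2.2-fold lower number from compound 3 to compound 4 (0.35 log units; beyond the scatter), which is beyond it. Nothing available explains these results. On these data alone, whether an amine, a carboxylic acid or a longer chain at this position would be tolerated remains open.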